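Chain Length and Liver-Cell Toxicity in an Amide Series

This account rests on a few compounds, and the source may have more. Where it says the series, first, only, none or still open, it means among the compounds named here.

Three measured compounds share one core and differ only in the acyl chain. Compound 1 `CC(=O)Nc1nc(N)nc2c1ncn2[C@H]1CO[C@@H](CO)O1` carries the shortest chain. In a functional assay on HepG2 cells (Homo sapiens) for cytotoxicity (on this read-out lower numbers stand for higher toxicity in this test and higher numbers for lower toxicity in this test), compound 1 gives only a limit, > 100000 nM. Compound 2 `CCCC(=O)Nc1nc(N)nc2c1ncn2[C@H]1CO[C@@H](CO)O1` also gives a limit, > 100000 nM. Compound 3 `CCCCCCCC(=O)Nc1nc(N)nc2c1ncn2[C@H]1CO[C@@H](CO)O1` likewise stops at a limit, > 100000 nM. The change ethyl in place of hydrogen on a saturated chain carbon bound to a carbonyl carbon produced a step that the two limits leave unreadable from compound 1 to compound 2, a reading that follows from the limit of > 100000 nM in this assay, at which 3 of the 3 values shown sit; the steps a step that the two limits leave unreadable from compound 1 to compound 3 and a step that the two limits leave unreadable from compound 2 to compound 3 are unreadable on the same ground, (the limit of > 100000 nM in this assay, at which 3 of the 3 values shown sit). Compound 4 `CCCCCCCCCC(=O)Nc1nc(N)nc2c1ncn2[C@H]1CO[C@@H](CO)O1` awaits measurement and differs from compound 3 by ethyl in place of hydrogen on a saturated chain carbon, seven bonds along the chain from a carbonyl carbon, while the core of compound 3 differs from that of compound 1 by hexyl in place of hydrogen on a saturated chain carbon bound to a carbonyl carbon. This is the same kind of change as before, yet the place differs: bound to a carbonyl carbon there, seven bonds along the chain from a carbonyl carbon here. Among the compounds with values here, since every value so far rests at the limit of > 100000 nM in this assay, at which 3 of the 3 values shown sit, the expected step is a number no higher from compound 3 to compound 4 (the limit leaves the size open). Compound 4 is estimated at 100000 nM, between 30000 nM and 300000 nM.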

Compound 4, half-maximal cytotoxic concentration: > 100000 nM
Compound 4: no number, only a limit; the forecaster's own chance of this, stated with the estimate: 70%; the middle value lies on the limit itself.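

Compound 4 also stops at a limit, so its steps from compound 1, compound 2 and compound 3 in this assay cannot be read: the limit of > 100000 nM in this assay, at which 4 of the 4 values shown sit.

The compounds shown leave open whether chain length changes the read-out in this assay at all.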